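The compounds below may be only part of what the source reports. "The series", "measured", "known", "first", "only" and "open" are said of these compounds alone.

Among the compounds with values here, compound 2 `O=C1c2c[n+]([O-])c3ccccc3c2C(=O)c2c1c1ccccc1n2CCCCN1CCCCC1` stands lowest of the two numbers so far in a functional assay on A-375 cells (Homo sapiens) for cytotoxicity, read by MTT assay, with a stated time of 72 h (on this read-out lower numbers stand for stronger inhibition and higher numbers for weaker inhibition), where compound 2 gives 190 nM, while compound 1 `O=C1c2c[n+]([O-])c3ccccc3c2C(=O)c2c1c1ccccc1n2CCCCN1CCNCC1` gives 460 nM. Within the data shown here, the single measured step, a 2.4-fold lower number from compound 1 to compound 2 (0.38 log units; beyond the scatter), exchanged one saturated ring amine for another at the end of the same chain. Compound 3 `O=C1c2c[n+]([O-])c3ccccc3c2C(=O)c2c1c1ccccc1n2CCCN1CCC(O)CC1` differs from compound 2 by 4-hydroxypiperidin-1-yl in place of (piperidin-1-yl)methyl on a saturated chain carbon, three bonds along the chain from an aromatic nitrogen. Among the measured compounds shown here, no measured step covers a shortened chain or an added hydroxyl group, so the direction is open and only a modest shift is expected. Compound 3 is therefore estimated at 320 nM, within 120 nM to 850 nM. That corresponds to an expected step of a 1.7-fold higher number from compound 2 to compound 3 (0.23 log units; within the scatter).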

Compound 3, half-maximal inhibitory concentration: 240 nM
Compound 3: middle estimate off by 1.3-fold (0.12 log units), on the high side; measured number inside the range.
By their numbers in this assay, from the lowest: compounds 2, 3 and 1 (each within the scatter of the next, the first and the last beyond it).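

In this assay, 3-(4-hydroxypiperidin-1-yl)propyl in place of 4-(piperidin-1-yl)butyl gives a 1.3-fold higher number from compound 2 to compound 3 (0.10 log units; within the scatter), so a shorter chain and an added hydroxyl together leave the number within the scatter of compound 2. The other comparison gives a 1.9-fold lower number from compound 1 to compound 3 (0.28 log units; within the scatter), also within the scatter, although compound 1 and compound 2 stand apart beyond it. No available evidence explains these numbers.

The compounds shown leave open what the shorter chain and the hydroxyl each do alone, as they change together here. As far as these compounds go, a 4-(4-hydroxypiperidin-1-yl)butyl chain would separate them, and a morpholin-4-yl group at the chain end remains open too.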